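Removing the pyridinylmethyl from the piperazine of compound 1

The source may report more compounds than this note shows. Statements on the series, on what has been measured and on what is new or still open speak of the compounds shown alone.

For the measured compounds named here, compound 1 `CN(C[C@H]1Cc2c(cccc2N2CCN(Cc3ccccn3)CC2)CN1)[C@H]1CCCc2cccnc21` stands lowest of the three compounds measured so far: in an ADME assay on microsomes from liver (Homo sapiens) for metabolic stability, read by LC-MS, with a stated time of 10 min (on this read-out higher numbers stand for a more stable compound and lower numbers for a less stable compound), compound 1 gives 4.2%. Compound 2 `C[C@@H]1CN(c2cccc3c2C[C@H](CN(C)[C@H]2CCCc4cccnc42)NC3)C[C@H](C)N1C` gives 24.6% in this assay, and compound 3 `c1cnc2c(c1)CCC[C@@H]2N(CC1CCCCC1)C[C@H]1Cc2c(cccc2N2CCNCC2)CN1` gives 81.6%; both gaps from compound 1 lie beyond the scatter. Compound 4 `CN(C[C@H]1Cc2c(cccc2N2CCNCC2)CN1)[C@H]1CCCc2cccnc21` has not yet been measured. Relative to compound 1 it differs in one place: hydrogen in place of (pyridin-2-yl)methyl on an amine nitrogen in a ring. Going by the values given here, no step between measured compounds isolates this change, so its direction cannot be read from the data; a small to moderate rise in this assay is expected, though a shift within the scatter remains possible. For compound 4 the estimate in this assay is 20%, between 4% and 55%, an expected step of a number 15.8 percentage points higher from compound 1 to compound 4 (beyond the scatter).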

Compound 4, percent of the compound remaining: 99.7%
Compound 4: the middle estimate sits 79.7 percentage points below what was measured; measured number outside the range, above it.
By their numbers in this assay, from the lowest: compound 1; then compound 2; then compound 3; then compound 4.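

Hydrogen in place of (pyridin-2-yl)methyl on the amine nitrogen in the ring gives a number 95.5 percentage points higher from compound 1 to compound 4 (beyond the scatter) in this assay, a large step that ties the low number of compound 1 to this one substituent. Piperazin-1-yl in place of 3,4,5-trimethylpiperazin-1-yl gives a similarly large a number 75.1 percentage points higher from compound 2 to compound 4 (beyond the scatter) on the same ring, while hydrogen in place of cyclohexyl elsewhere gives a modest a number 18.1 percentage points higher from compound 3 to compound 4 (beyond the scatter) in the same direction. Nothing measured here explains these steps.

As far as these compounds go, whether an acetyl group or a short chain ending in a carboxylic acid on that nitrogen would hold the number of compound 4 stays open.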